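A few compounds are considered here, and "the series" means these few. Any claim that something is new, unique, unknown or untested is made for them only; others in the source may bear on it.

Three compounds have numbers in a functional assay on CHO cells for antagonist activity at C-X-C chemokine receptor type 3 (Homo sapiens), read by GTPgammaS binding, with a stated time of 30 min; on this read-out higher numbers stand for weaker inhibition and lower numbers for stronger inhibition. Compound 1 `O=C1CCC(c2cccnc2)(C2CCN(Cc3ccc(Br)cc3)CC2)C(=O)N1` gives 1000 nM, compound 2 `O=CN1CCCC(c2ccccc2)(C2CCN(Cc3ccc(Br)cc3)CC2)C1` gives 150 nM, and compound 3 `O=C(N1CCCC(c2ccccc2)(C2CCN(Cc3ccc(Br)cc3)CC2)C1)C(F)(F)F` gives 690 nM. Compound 3 thus stands second highest of the three, nearest to compound 1 and furthest from compound 2. Within the data shown here, the one measured step between compounds differing in a single place is a 4.6-fold higher number from compound 2 to compound 3 (0.66 log units; beyond the scatter), the change being trifluoromethyl in place of hydrogen on a carbonyl carbon, a modest step. Compound 4 `CCC(=O)N1CCCC(c2ccccc2)(C2CCN(Cc3ccc(Br)cc3)CC2)C1` differs from compound 3 in one place: ethyl in place of trifluoromethyl on a carbonyl carbon. Among the measured compounds shown here, only that step bears on this change. Ethyl is neither hydrogen nor trifluoromethyl, so compound 4 is expected to land between compound 2 and compound 3, a step of a 2.0-fold lower number from compound 3 to compound 4 (0.29 log units; within the scatter) that may not reach beyond the scatter. Compound 4 is therefore estimated at 350 nM in this assay, with a range from 120 nM to 1000 nM.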

Compound 4, half-maximal inhibitory concentration: 290 nM
Compound 4: middle estimate off by 1.2-fold (0.08 log units), on the high side; the measured number falls inside the stated range.
By their numbers in this assay, from the lowest: compounds 2 and 4 (each within the scatter of the next); then compounds 3 and 1 (each within the scatter of the next).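

On this carbonyl carbon, in this assay, ethyl in place of trifluoromethyl gives a modest gain (a 2.4-fold lower number from compound 3 to compound 4 (0.38 log units; beyond the scatter)). Ethyl in place of hydrogen gives a step that stays within the scatter (a 1.9-fold higher number from compound 2 to compound 4 (0.29 log units; within the scatter)), so unlike trifluoromethyl, ethyl shows no clear loss against hydrogen. Nothing available explains why these two groups differ. The compounds shown leave open whether a longer chain, a methoxy group or an amine on this carbonyl carbon would also stay within the scatter of compound 2.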